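Lipophilicity in a four-compound series of diastereomeric pairs

The source may report more compounds than this note shows. Statements on the series, on what has been measured and on what is new or still open speak of the compounds shown alone.

Compound 1 `Cn1nccc1-c1cc(C(F)(F)F)ccc1[C@H]1CCOc2cc(S(=O)(=O)Nc3nccs3)ccc21` and compound 3 `Cn1nccc1-c1cc(C(F)(F)F)ccc1[C@@H]1CCOc2cc(S(=O)(=O)Nc3nccs3)ccc21` are built from the same atoms and bonds and differ only in configuration as drawn: the two compounds have the same atoms and bonds and differ only in configuration as drawn: 1 of 1 stereo elements differ; a stereocentre at a saturated ring carbon is drawn R in compound 1 and S in compound 3. In a physicochemical assay for lipophilicity (a higher number here means a more lipophilic compound, a lower number a more polar compound), compound 1 gives 2.2, and compound 3 gives 2.2. The step of no change at the digits printed from compound 1 to compound 3 (within the scatter) fits (the fact that compounds 1 and 3 differ only in the configuration as drawn), and together the two compounds hold the lowest numbers of the three measured.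

Compound 2 `O=S(=O)(Nc1nccs1)c1ccc2c(c1)OCC[C@@H]2c1ccc(C(F)(F)F)cc1-c1ccc(F)cc1` is reached from compound 1 by a single replacement, (4-fluorophenyl in place of 1-methyl-1H-pyrazol-5-yl on an aromatic carbon). In this assay compound 2 gives 4.5, so the replacement made a step of a number 2.30 log units higher from compound 1 to compound 2 (beyond the scatter).

Compound 4 `O=S(=O)(Nc1nccs1)c1ccc2c(c1)OCC[C@H]2c1ccc(C(F)(F)F)cc1-c1ccc(F)cc1` has not been measured. It differs from compound 3 by 4-fluorophenyl in place of 1-methyl-1H-pyrazol-5-yl on an aromatic carbon. The change is the same as the one from compound 1 to compound 2, at a place described in identical words, and it occurs twice among the compounds shown. Compound 4 stands to compound 2 exactly as compound 3 stands to compound 1, differing only in configuration as drawn.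

The step from compound 3 to compound 4 in this assay is expected to be a number 2.30 log units higher from compound 3 to compound 4 (beyond the scatter), beside the measured step of a number 2.30 log units higher from compound 1 to compound 2 (beyond the scatter); this expectation rests on compound 3 matching compound 1 with no change at the digits printed from compound 1 to compound 3 (within the scatter), so configuration alone appears not to move the reading here. Compound 4 is therefore estimated at 4.5, expected to fall between 4.1 and 4.9.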

Compound 4, distribution coefficient: 4.5
For compound 4 middle estimate and measured number coincide at the digits printed, and the stated range covers the measured number.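

In this assay the replacement of 1-methyl-1H-pyrazol-5-yl by 4-fluorophenyl gives a number 2.30 log units higher from compound 3 to compound 4 (beyond the scatter), which matches a number 2.30 log units higher from compound 1 to compound 2 (beyond the scatter), so at the digits printed this change carries over in full from the core of compound 1 to the core of compound 3. The reading also stays in place within the 4-fluorophenyl pair, with no change at the digits printed from compound 2 to compound 4 (within the scatter), but this is a narrow test of transfer, because the two sides of the pair differ by configuration alone: the fact that compounds 2 and 4 differ only in the configuration as drawn The result does not show that the step would keep its size on a core with different atoms and bonds, or that any other replacement would carry over in the same way, since the series shown holds one replacement at one place on two stereo forms of one core.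

The compounds shown leave open how the reading would respond to other groups at this aromatic carbon, such as an amine, a carboxylic acid or a longer alkyl chain in place of 1-methyl-1H-pyrazol-5-yl or 4-fluorophenyl. They also leave open whether the two configurations would stay level in any read-out other than this assay.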